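The compounds below may be only part of what the source reports. "The series", "measured", "known", "first", "only" and "open" are said of these compounds alone.

Of the compounds shown here, two have been measured so far. Compound 1 `Nc1nc(NCc2cccs2)nc2sc(-c3cccs3)nc12` gives 73 nM in an assay on CHO cells for displacement of a labelled ligand from adenosine receptor A1 (Homo sapiens), read by scintillation counting, with a stated time of 90 min; a higher number here means a weaker inhibitor, a lower number a stronger inhibitor. Compound 2 `Nc1nc(NCc2cccnc2)nc2sc(-c3ccco3)nc12` gives 7.12 nM in this assay, the lowest of the two numbers, with compound 1 standing beyond the scatter above it. Compound 3 `Nc1nc(NCc2cnccn2)nc2sc(-c3ccco3)nc12` carries the change (pyrazin-2-yl in place of pyridin-3-yl on a saturated chain carbon bound to a nitrogen on an aromatic ring), the swap sitting on a saturated chain carbon bound to a nitrogen on an aromatic ring. Within the data shown here, no measured pair shows this change, so the expectation rests on compound 2 alone. The step is expected to be small, likely none beyond the scatter, at a 1.4-fold higher number from compound 2 to compound 3 (0.15 log units; within the scatter). Compound 3 is expected to give 10 nM in this assay, within a range from 3 nM to 35 nM.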

Compound 3, inhibition constant: 25 nM
The estimate for compound 3 lay 2.5-fold (0.40 log units) below the measured number; the measured number falls inside the stated range.
By their numbers in this assay, from the lowest: compound 2; then compound 3; then compound 1.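

In this assay, among these compounds, this place on a saturated chain carbon bound to a nitrogen on an aromatic ring proves sensitive to the ring it carries: pyrazin-2-yl in place of pyridin-3-yl gives a 3.5-fold higher number from compound 2 to compound 3 (0.55 log units; beyond the scatter), the first single-place step. The change adds a ring hetero atom and a hydrogen-bond acceptor, and the number rises modestly. Nothing available explains this rise.

Going by these compounds, it remains open how a phenyl ring at this place, or a longer chain carrying the pyridin-3-yl, would read. A single step also cannot separate the effect of the second ring nitrogen from that of where the ring is attached.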